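Pyridin-2-yl in Place of 3-Fluorophenyl on a Weak Series

The source may report more compounds than this note shows. Statements on the series, on what has been measured and on what is new or still open speak of the compounds shown alone.

Compound 1 `COc1ccc(C(=O)/C=C/c2cccc(F)c2)c2c1C=CC(C)(C)O2`: in a functional assay on SK-OV-3 cells (Homo sapiens) for antiproliferative activity, read by MTT assay, with a stated time of 24 h (on this read-out higher numbers stand for weaker inhibition and lower numbers for stronger inhibition), compound 1 gives > 10000 nM, a limit of the assay rather than a number.
Compound 2 `COc1ccc(C(=O)/C=C/c2cccc(C(F)(F)F)c2)c2c1C=CC(C)(C)O2`: in this assay compound 2 gives 9330 nM.
Compound 3 `COc1ccc(C(=O)/C=C/c2cccc3ccccc23)c2c1C=CC(C)(C)O2`: in this assay compound 3 gives > 10000 nM, again a limit of the assay.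

Compound 1 therefore stands at the limit of this assay, and so does compound 3; only compound 2 returns a number, and that number sits close to the same limit. Among the compounds with values here, the one step that joins two measured compounds in a single change is an at least 1.0-fold lower number from compound 1 to compound 2 (0.03 log units; that floor lies within the scatter), which is a trifluoromethyl in place of fluoro on an aromatic carbon and does not leave the scatter. The evidence is summarised by the limit of > 10000 nM in this assay, at which 2 of the 3 values shown sit.

Compound 4 `COc1ccc(C(=O)/C=C/c2ccccn2)c2c1C=CC(C)(C)O2` differs from compound 1 by pyridin-2-yl in place of 3-fluorophenyl on a double-bonded chain carbon bound to a double-bonded chain carbon. Within the data shown here, no measured step touches this ring swap, so nothing in the data points to a direction. The series as a whole sits at or near the limit, and compound 4 is expected to stay there. Compound 4 is estimated at 10000 nM, with a range from 4000 nM to 30000 nM. The step of a number no higher from compound 1 to compound 4 (the limit leaves the size open) is expected to lie within the scatter, with a fair chance that only a limit is reported.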

Compound 4, half-maximal inhibitory concentration: 8390 nM
Compound 4: the middle estimate sits 1.2-fold (0.08 log units) above what was measured; the measured number falls inside the stated range.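

With compound 4 the change reaches the aromatic ring itself rather than a group on it, putting a six-membered aromatic ring with 1 hetero atom and 1 hydrogen-bond acceptor in place of one of carbon only, on a double-bonded chain carbon bound to a double-bonded chain carbon. In this assay, within the data shown here, this swap reads as an at least 1.1-fold lower number from compound 1 to compound 4 (0.07 log units; that floor lies within the scatter), so the first measured step at this place does not leave the scatter, and its true size stays open. The swap therefore does not lift the series clear of its limit, which still marks much of the data: the limit of > 10000 nM in this assay, at which 2 of the 4 values shown sit.

The compounds shown leave open whether pyridin-3-yl, pyridin-4-yl or a phenyl ring carrying an amine or a carboxylic acid would give a step beyond the scatter at this place. They also leave open whether pyridin-2-yl would read the same way on a compound with other groups on the shared core.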